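The compounds below may be only part of what the source reports. "The series", "measured", "known", "first", "only" and "open" are said of these compounds alone.

Measured so far in an ADME assay on microsomes from liver (Mus musculus, strain CD-1) for metabolic stability, read by LC-MS, with a stated time of 60 min, tested at 20 uM; on this read-out lower numbers stand for a shorter-lived compound and higher numbers for a longer-lived compound:

- compound 1, `Cn1ncc2c(=O)n(-c3ccccc3)c(SCc3cccc(F)c3)nc21` — 0.133 h
- compound 2, `CC(Sc1nc2nn(C3COC3)cc2c(=O)n1-c1ccccc1)c1cccnc1` — 0.045 h

Compound 1 holds the higher of the two numbers. Compound 2, whose value in this assay is the lower of the two, sits beyond the usual scatter below it, so compound 1 is the longer-lived of the pair as far as these two values go. The two structures differ in more than one place, so no single change can be read from that gap.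

Compound 3, `C[C@@H](Sc1nc2c(cnn2C)c(=O)n1-c1ccccc1)c1ccccc1`, has not yet been run in this assay. It differs from compound 1 at one spot only:

1-phenylethyl in place of 3-fluorobenzyl on a sulfur

Going by the values given here, nothing among the measured pairs isolates this change, so the direction of its effect cannot be inferred from anything here. Compound 3 is therefore expected to stay close to compound 1, with the step of a 1.1-fold lower number from compound 1 to compound 3 (0.04 log units; within the scatter) lying within the usual scatter rather than beyond it. On that basis compound 3 is estimated at 0.12 h in this assay, with a likely range from 0.05 h to 0.3 h.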

Compound 3, half-life: 0.133 h
Beside the measured number, compound 3's estimate is 1.1-fold (0.04 log units) below it; low and high end bracket the measured number.
By their numbers in this assay, from the lowest: compound 2; then compounds 1 and 3 (each within the scatter of the next).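

In this assay, going by these compounds alone, placing 1-phenylethyl in place of 3-fluorobenzyl on a sulfur whose other neighbours are aromatic carbon gives no change at the digits printed from compound 1 to compound 3 (within the scatter), the first reading of a single change at this position. The half-life therefore does not separate these two groups, even though the change removes the fluorine and brings in a defined stereocentre, while the heavy-atom count and the single six-membered aromatic ring stay the same. Nothing measured here offers a reason for this result.

Because the fluorine and the branched carbon change together in this one step, the compounds shown leave open how each would read alone, which a plain benzyl group on the sulfur would begin to separate, and they also leave open how the opposite stereocentre of 1-phenylethyl would read. They likewise do not show whether the position stays this flat for a group of a different kind, such as a longer chain like 3-phenylpropyl or a group carrying an amine or a carboxylic acid.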